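Compound 3: methoxy to hydroxy in a small series

The source may report more compounds than this note shows. Statements on the series, on what has been measured and on what is new or still open speak of the compounds shown alone.

Of the compounds shown here, two have been measured so far in a functional assay on A549 cells (Homo sapiens) for inhibition, read by MTT assay, with a stated time of 72 h; a higher number here means a weaker inhibitor, a lower number a stronger inhibitor. Compound 1 (`COc1ccc(/C=C/C(=O)c2c(OC)cc(O)c(CC=C(C)C)c2O)cc1`) gives 38000 nM. Compound 2 (`COc1cc(/C=C/C(=O)c2c(OC)cc(O)c(CC=C(C)C)c2O)ccc1O`) gives 11800 nM, the lower of the two numbers and so the stronger result in this small set.

Compound 3 (`COc1cc(O)c(CC=C(C)C)c(O)c1C(=O)/C=C/c1ccc(O)c(O)c1`) differs from compound 2 in one place: hydrogen in place of methyl on an oxygen on an aromatic ring. This is hydrogen in place of methyl on an oxygen on an aromatic ring, turning 4-hydroxy-3-methoxyphenyl into 3,4-dihydroxyphenyl.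

Among the compounds with values here, only one measured step bears on this change: a 3.2-fold lower number from compound 1 to compound 2 (0.51 log units; beyond the scatter). That step is modest but beyond the scatter, and it ends at the 4-hydroxy-3-methoxyphenyl group of compound 2. It is a different change from the one at hand, and a single step sets no pattern, so it offers only a weak guide. A smaller move towards a lower number is expected in this assay, and no real change remains possible. The estimated step is a 1.6-fold lower number from compound 2 to compound 3 (0.20 log units; within the scatter). For compound 3 the estimated value is 7500 nM, with an expected range from 3000 nM to 18000 nM.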

Compound 3, half-maximal inhibitory concentration: 16100 nM
Estimate against measurement, compound 3: 2.1-fold (0.33 log units) below; the measured number falls inside the stated range.
By their numbers in this assay, from the lowest: compounds 2 and 3 (each within the scatter of the next); then compound 1.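

Within this assay, turning 4-hydroxy-3-methoxyphenyl into 3,4-dihydroxyphenyl gives a 1.4-fold higher number from compound 2 to compound 3 (0.13 log units; within the scatter) and so no readable difference: on this oxygen on an aromatic ring, methyl and hydrogen are not told apart by this read-out. Measured against the 4-methoxyphenyl group, 3,4-dihydroxyphenyl gives a 2.4-fold lower number from compound 1 to compound 3 (0.37 log units; beyond the scatter) and keeps a modest separation, so compound 2 and compound 3, which both carry the hydroxy group named at the 4 position, stand apart from compound 1 in the same direction. Nothing in hand explains these numbers.

Still open, as far as these compounds go, is whether the separation from compound 1 rests on that hydroxy alone, which a plain 4-hydroxyphenyl group would test, and whether an amine or a fluorine in its place would keep the number near those of compound 2 and compound 3. The shared core is the same across all three compounds, so these notes say nothing about how much its other groups, such as the methoxy on the second aromatic ring or the chain on that ring, contribute to the read-out.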